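Swapping 2-chlorophenyl for 4-methylphenyl on the shared core

A few compounds are considered here, and "the series" means these few. Any claim that something is new, unique, unknown or untested is made for them only; others in the source may bear on it.

In a functional assay on HT-29 cells (Homo sapiens) for inhibition, read by MTT assay, with a stated time of 48 h (a higher number here means a weaker inhibitor, a lower number a stronger inhibitor), compound 1 (`O=C1N/C(=N\Cc2cccc(Cl)c2)S/C1=C1/CCNC(=O)c2[nH]ccc21`) gives 35300 nM. Compound 2 (`O=C1N/C(=N\Cc2ccccc2Cl)S/C1=C1/CCNC(=O)c2[nH]ccc21`) gives > 100000 nM, which is a limit of the assay and not a number. Within the data shown here, the only measured step is an at least 2.8-fold higher number from compound 1 to compound 2 (0.45 log units; beyond the scatter), with 2-chlorophenyl in place of 3-chlorophenyl. This shows that the chlorine-bearing group can shift the result beyond the usual scatter.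

Compound 3 (`Cc1ccc(C/N=C2\NC(=O)/C(=C3\CCNC(=O)c4[nH]ccc43)S2)cc1`) carries 4-methylphenyl in place of 2-chlorophenyl on a saturated chain carbon bound to a double-bonded nitrogen. Compound 3 no longer has the 2-chlorophenyl group, so the closest guide is compound 1 at 35300 nM. A modest move to a lower number in this assay is therefore expected, though another limit reading remains possible. The expected change is an at least 2.0-fold lower number from compound 2 to compound 3 (0.30 log units; that floor lies within the scatter). For compound 3 the estimate is 50000 nM, with an expected range of 15000 nM to 100000 nM.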

Compound 3, half-maximal inhibitory concentration: 6830 nM
The estimate for compound 3 lay 7.3-fold (0.86 log units) above the measured number, and the stated range ends above it.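

The group on a saturated chain carbon bound to a double-bonded nitrogen can matter far more than the move of the chlorine alone suggested: in this assay, 4-methylphenyl in place of 2-chlorophenyl gives an at least 14-fold lower number from compound 2 to compound 3 (1.16 log units; beyond the scatter), and 4-methylphenyl in place of 3-chlorophenyl gives a 5.2-fold lower number from compound 1 to compound 3 (0.71 log units; beyond the scatter). Compound 2 stands at a limit and not at a number, so its step gives only a floor for the change: the limit of > 100000 nM in this assay, at which 1 of the 3 values shown sits. Compound 3, the one of the three without chlorine, is the strongest inhibitor shown.

Chlorine and methyl also differ in where they sit on the ring, so the compounds shown cannot separate the identity of the group from its place. As far as these compounds go, how a ring carrying an amine or a carboxylic acid would read in this assay also stays open.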